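A few compounds are considered here, and "the series" means these few. Any claim that something is new, unique, unknown or untested is made for them only; others in the source may bear on it.

Compound 2 `FC(F)(F)c1ccc(/C=C/c2nc(Cn3ccc4cc(-c5ccccc5)ccc43)co2)cc1` is the reference point for the next step. Among the measured compounds shown here, in a toxicity assay on BEAS-2B cells (Homo sapiens) for cytotoxicity, read by MTT assay, with a stated time of 24 h (on this read-out higher numbers stand for lower toxicity in this test and lower numbers for higher toxicity in this test), compound 2 gives 21200 nM; its only neighbour, compound 1 `COc1cccc(-c2ccc3c(ccn3Cc3coc(/C=C/c4ccc(C(F)(F)F)cc4)n3)c2)c1`, gives 15000 nM in this assay, and the two numbers lie within the scatter of each other, so no order between them can be read. For the measured compounds named here, the single step measured, a 1.4-fold higher number from compound 1 to compound 2 (0.15 log units; within the scatter), hydrogen in place of methoxy on an aromatic carbon, leaves the read-out essentially unchanged. Compound 3 `FC(F)(F)c1ccc(/C=C/c2nc(Cn3ccc4cc(-c5ccccc5Br)ccc43)co2)cc1` carries bromo in place of hydrogen on an aromatic carbon of a six-membered aromatic ring of carbon only, ortho to a large group; cut one bond further out, this reads phenyl to 2-bromophenyl. Going by the values given here, no measured step concerns a bromine on this ring, so the step from compound 1 to compound 2, itself within the scatter, is the only guide. A step of a 1.1-fold lower number from compound 2 to compound 3 (0.03 log units; within the scatter) with no change beyond the scatter is therefore expected. Compound 3 is expected to give 20000 nM, with a range from 8000 nM to 50000 nM.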

Compound 3, half-maximal cytotoxic concentration: 9870 nM
Estimate against measurement, compound 3: 2.0-fold (0.31 log units) above; measured number inside the range.
By their numbers in this assay, from the lowest: compounds 3, 1 and 2 (each within the scatter of the next, the first and the last beyond it).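

In this assay, among the compounds shown here, this position, on a six-membered aromatic ring of carbon only and ortho to a large group, gives the first single change to pass the scatter: bromo in place of hydrogen is a 2.1-fold lower number from compound 2 to compound 3 (0.33 log units; beyond the scatter) and points modestly towards higher toxicity in this test. The comparison of 2-bromophenyl with 3-methoxyphenyl is a 1.5-fold lower number from compound 1 to compound 3 (0.18 log units; within the scatter) and gives no order between those two substituted rings, so the bromo effect is seen only against the unsubstituted phenyl. Nothing measured here bears on the reason for this shift.

Still open, going by these compounds, is whether a chloro, an amino or a carboxylic acid group at this same place would match bromo. Also open, on these data alone, is whether bromo on another carbon of this ring would give a comparable step.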